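This account rests on a few compounds, and the source may have more. Where it says the series, first, only, none or still open, it means among the compounds named here.

Compound 1 `O=C(CCCCC1CCSS1)Nc1ccc(OC(F)(F)F)cc1`: 1.54%
Compound 2 `O=C(CCCCC(S)CCS)Nc1ccc(OC(F)(F)F)cc1`: 6%

In a functional assay on KB cells (Homo sapiens) for inhibition, read by MTT assay, with a stated time of 24 h, tested at 1 ug/mL (a higher number here means more inhibition of growth at the concentration tested, a lower number less inhibition of growth), compound 2 gives 6% and compound 1 gives 1.54%, so the two values lie within the scatter of each other. Compound 3 `O=C(CCCCC(S)CCS)Nc1ccc([N+](=O)[O-])cc1` has nitro in place of trifluoromethoxy on an aromatic carbon. Going by the values given here, the only measured step, a number 4.5 percentage points higher from compound 1 to compound 2 (within the scatter), concerns the sulfur-bearing chain and leaves this aromatic group untouched. No measurement therefore shows what this swap does, and no change beyond the scatter is expected in this assay. The expected step is a number 1 percentage points higher from compound 2 to compound 3 (within the scatter). For compound 3 the estimated value is 7%, with an expected range of 0% to 20%.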

Compound 3, percent growth inhibition at one concentration: 0.93%
Estimate against measurement, compound 3: 6.1 percentage points above, within the range that was stated.
By their numbers in this assay, from the lowest: compounds 3, 1 and 2 (each within the scatter of the next).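

Replacing trifluoromethoxy with nitro on the aromatic ring gives, in this assay, a number 5.1 percentage points lower from compound 2 to compound 3 (within the scatter), so this assay does not separate the two groups at this position. Going by these compounds alone, this is the first reading of a change on the ring, as the earlier step concerned only the sulfur-bearing chain. No measured evidence bears on this result.

On these data alone, it remains open whether an amine or a carboxylic acid at this position would shift growth inhibition beyond the scatter. As far as these compounds go, it also remains open whether a longer chain on the sulfur-bearing side would do so.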